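Sulfonamide aryl swap where every anchor is a limit

This account rests on a few compounds, and the source may have more. Where it says the series, first, only, none or still open, it means among the compounds named here.

Compound 1, `O=S(=O)(Nc1ccc(Cl)c(F)c1)c1ccc(-c2cnc(C3CC3)o2)cc1`, was tested in a functional assay on cells (leukaemia cell line, Homo sapiens) for inhibition, read by sulforhodamine B assay, with a stated time of 48 h; on this read-out lower numbers stand for higher toxicity in this test and higher numbers for lower toxicity in this test. In this assay compound 1 returns only a limit, > 100000 nM. Compound 2, `O=S(=O)(Nc1cccc(Cl)c1)c1ccc(-c2cnc(C3CC3)o2)cc1`, also gives only a limit, > 100000 nM. Compound 3, `O=S(=O)(Nc1ccc(F)cc1F)c1ccc(-c2cnc(C3CC3)o2)cc1`, likewise stops at a limit, > 100000 nM. All three rest on (the limit of > 100000 nM in this assay, at which 3 of the 3 values shown sit), so the steps a step that the two limits leave unreadable from compound 1 to compound 2, a step that the two limits leave unreadable from compound 1 to compound 3 and a step that the two limits leave unreadable from compound 2 to compound 3 cannot be read. Compound 4, `Cc1ccc(Cl)c(NS(=O)(=O)c2ccc(-c3cnc(C4CC4)o3)cc2)c1`, is the next variant: 2-chloro-5-methylphenyl in place of 4-chloro-3-fluorophenyl on a sulfonamide nitrogen. Each measured step alters the same group on the sulfonamide nitrogen without yielding a readable number, so for this step no readable change is expected either, giving an estimated a number no higher from compound 1 to compound 4 (the limit leaves the size open). Compound 4 is therefore expected near 100000 nM, within 30000 nM to 300000 nM, most likely again as a limit.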

Compound 4, concentration lethal to 50% of the cells: > 100000 nM
Compound 4 gave a limit, no number; the forecaster's own chance of this, stated with the estimate: 80%; the middle value sits exactly at the limit.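

Compound 4 also stops at a limit, so its steps from compound 1, compound 2 and compound 3 cannot be read, and all four compounds rest on the same limit: the limit of > 100000 nM in this assay, at which 4 of the 4 values shown sit. The compounds shown leave open whether any group on the sulfonamide nitrogen gives a readable number in this assay.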